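The source may hold more compounds than are shown below. What is called first, only, known or untested is meant among the compounds shown, and "the series" means these compounds.

In a functional assay on HepG2 cells (Homo sapiens) for cytotoxicity, read by sulforhodamine B assay, with a stated time of 48 h (a lower number here means a stronger inhibitor, a higher number a weaker inhibitor), three compounds have a record so far:

compound 1 `COc1ccc(/C=C/C(=O)c2ccc(N)c(-c3ccc(F)cc3)c2)cc1O` gives "not determined" (no result reported)
compound 2 `COc1ccc(/C=C/C(=O)c2cccc(-c3ccc(F)cc3)c2)cc1` gives 5650 nM
compound 3 `COc1cc(/C=C/C(=O)c2ccc(N)c(-c3ccc(F)cc3)c2)cc(Br)c1O` gives 4730 nM

Compound 3 and compound 2 lie within the scatter of each other, and compound 1 has no number to set beside them. Compound 4 `COc1cc(/C=C/C(=O)c2ccc(N)c(-c3ccc(F)cc3)c2)ccc1O` departs from compound 3 at a single place (hydrogen in place of bromo on an aromatic carbon) with hydrogen in place of bromo on an aromatic carbon, ortho to a hydroxy group. Within the data shown here, no measured pair isolates this change, so the step in this assay can only be judged indirectly. Compound 2 carries no bromo and gives 5650 nM within the scatter of compound 3, although it differs elsewhere too. Removing the bromo is therefore not expected to move the number far. The expected change is a 1.3-fold higher number from compound 3 to compound 4 (0.10 log units; within the scatter) and would be a small one towards a higher number, not beyond the scatter. For compound 4 the estimated value is 6000 nM with an expected range from 2500 nM to 15000 nM on repeated measurement.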

Compound 4, half-maximal inhibitory concentration: 4300 nM
Beside the measured number, compound 4's estimate is 1.4-fold (0.14 log units) above it; the range from low to high includes it.
By their numbers in this assay, from the lowest: compounds 4, 3 and 2 (each within the scatter of the next).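

The direct pair now settles what compound 2 could only suggest, since compound 2 differs from compound 3 elsewhere too. In this assay, hydrogen in place of bromo on this aromatic carbon, ortho to a hydroxy group, gives a 1.1-fold lower number from compound 3 to compound 4 (0.04 log units; within the scatter), so compound 3 and compound 4 cannot be told apart at this position and the bromo is not needed to keep this level of cytotoxicity. Nothing available accounts for the two groups reading alike.

On these data alone, only bromo and hydrogen are compared on this carbon, so it remains open whether chlorine, an amine or a carboxylic acid there would leave the number equally unmoved. Among these compounds, whether the same holds on a core without the amino group also remains open, as no pair tests this.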